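A few compounds are considered here, and "the series" means these few. Any claim that something is new, unique, unknown or untested is made for them only; others in the source may bear on it.

Three close relatives of one hydrazone core have been tested in a functional assay on C6 cells (Rattus norvegicus) for cytotoxicity, read by MTT assay, with a stated time of 24 h; a lower number here means a stronger inhibitor, a higher number a weaker inhibitor. Compound 1 `Cc1nnc(SCC(=O)N/N=c2/scc(-c3ccc(Cl)cc3)n2-c2ccccc2)s1` gives 28 ug/mL. Compound 2 `Cc1ccc(-c2cs/c(=N/NC(=O)CSc3nnnn3-c3ccccc3)n2-c2ccccc2)cc1` gives 14.7 ug/mL, the lowest number of the three, and compound 3 `Cc1ccc(-c2cs/c(=N/NC(=O)CSc3nnnn3C)n2-c2ccccc2)cc1` gives 36.3 ug/mL. Of these, the step from compound 2 to compound 1 lies within the scatter, whereas the step of a 2.5-fold higher number from compound 2 to compound 3 (0.39 log units; beyond the scatter), a methyl in place of a phenyl on the aromatic nitrogen of the tetrazole, goes beyond it.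

Compound 4 `O=C(CSc1nnnn1-c1ccccc1)N/N=c1/scc(-c2ccc(Cl)cc2)n1-c1ccccc1` is not yet measured. It differs from compound 2 in one place: chloro in place of methyl on an aromatic carbon. Among the measured compounds shown here, no measured pair isolates exactly this swap; compound 1 also carries a chloro group but differs from compound 2 in a second place as well, so their two values show only that they sit within the scatter of each other. For the measured compounds named here, with no directly bearing step, the expectation is that compound 4 stays near compound 2, with a step of a 1.2-fold higher number from compound 2 to compound 4 (0.09 log units; within the scatter) that is not expected to exceed the scatter. Compound 4 is therefore estimated at 18 ug/mL, within a range from 8 ug/mL to 40 ug/mL.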

Compound 4, half-maximal inhibitory concentration: > 200 ug/mL
Compound 4: no number, only a limit; the forecaster's own chance of this, stated with the estimate: 5%; at least 11-fold (1.04 log units) between middle value and limit.
By their numbers in this assay, from the lowest: compounds 2, 1 and 3 (each within the scatter of the next, the first and the last beyond it). At a limit, above all of these: compound 4.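

In this assay, compound 4 has no number, only a limit: the limit of > 200 ug/mL in this assay, at which 1 of the 4 values shown sits. Swapping 4-methylphenyl to 4-chlorophenyl gives an at least 13-fold higher number from compound 2 to compound 4 (1.13 log units; beyond the scatter), so this place on the ring, untested by the earlier compounds, can have a large effect on the read-out. The chloro group alone does not account for this, since the swap of 5-methyl-1,3,4-thiadiazol-2-yl to 1-phenyl-1H-tetrazol-5-yl on the sulfur, with 4-chlorophenyl kept, gives an at least 7.1-fold higher number from compound 1 to compound 4 (0.85 log units; beyond the scatter), which suggests that the outcome depends on the two places together.

The compounds shown leave open whether the weakening follows from chloro itself or from the loss of methyl, a question that a fluoro, methoxy or ethyl group at this place would help to settle. They also leave open how a 1-methyl-1H-tetrazol-5-yl group on the sulfur would behave alongside 4-chlorophenyl.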